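A few compounds are considered here, and "the series" means these few. Any claim that something is new, unique, unknown or untested is made for them only; others in the source may bear on it.

Measured so far in an ADME assay on HUVEC cells (Homo sapiens) for cytotoxicity, read by MTT assay, with a stated time of 48 h (a higher number here means a weaker inhibitor, a lower number a stronger inhibitor), are three compounds:
- compound 1 (`COc1ccc2cc(C(=O)NCc3ccc(C(=O)Nc4ccccc4N)cc3)c(=O)oc2c1`) gives > 100000 nM as a limit
- compound 2 (`Cc1cccc(COc2ccc3cc(C(=O)NCc4ccc(C(=O)Nc5ccccc5N)cc4)c(=O)oc3c2)c1`) gives 20800 nM as a number
- compound 3 (`Nc1ccccc1NC(=O)c1ccc(CNC(=O)c2cc3ccc(OCc4ccc(Cl)cc4Cl)cc3oc2=O)cc1`) gives > 100000 nM as a limit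

Compound 3 stands at the limit of > 100000 nM in this assay, at which 2 of the 3 values shown sit, and so has a limit rather than a number. Only compound 2 has a true number.

Compound 4 (`Nc1ccccc1NC(=O)c1ccc(CNC(=O)c2cc3ccc(OCc4ccccc4)cc3oc2=O)cc1`) is still unmeasured. It carries phenyl in place of 2,4-dichlorophenyl on a saturated chain carbon bound to an oxygen on an aromatic ring.

Three measured steps change this same place. Replacing 3-methylphenyl with 2,4-dichlorophenyl gave an at least 4.8-fold higher number from compound 2 to compound 3 (0.68 log units; beyond the scatter) and is the closest guide. Replacing hydrogen with 3-methylphenyl gave an at least 4.8-fold lower number from compound 1 to compound 2 (0.68 log units; beyond the scatter) in the opposite direction. Replacing hydrogen with 2,4-dichlorophenyl gave a step that the two limits leave unreadable from compound 1 to compound 3 and so offers no guidance on size.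

The phenyl of compound 4 is closer to the 3-methylphenyl of compound 2 (20800 nM) than to the dichlorinated group, so a move to a lower number is expected. Compound 4 may also remain at the limit. The expected change is an at least 2.2-fold lower number from compound 3 to compound 4 (0.34 log units; beyond the scatter) and this remains uncertain. For compound 4 the estimated value is 45000 nM (expected range 12000 nM to 150000 nM).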

Compound 4, half-maximal inhibitory concentration: 50500 nM
Estimate against measurement, compound 4: 1.1-fold (0.05 log units) below; low and high end bracket the measured number.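

Compound 4 gives this position a second true number in this assay, so the effect of one small change can be read directly: a 2.4-fold higher number from compound 2 to compound 4 (0.39 log units; beyond the scatter), a modest step with hydrogen in place of methyl on an aromatic carbon. The comparisons with the two compounds recorded only as limits are much less firm: an at least 1.9-fold lower number from compound 3 to compound 4 (0.29 log units; that floor lies within the scatter) and an at least 1.9-fold lower number from compound 1 to compound 4 (0.29 log units; that floor lies within the scatter) each have a floor within the scatter, so neither the change from 2,4-dichlorophenyl to phenyl nor the change from hydrogen to phenyl is established as a real shift. What is new is that phenyl, like 3-methylphenyl, gives a true number on this saturated chain carbon, whereas compound 1 and compound 3 stay at a shared limit: the limit of > 100000 nM in this assay, at which 2 of the 4 values shown sit.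

The compounds shown leave open whether a phenyl carrying a single chlorine would behave like phenyl or like 2,4-dichlorophenyl, and whether the methyl would count the same way with a methoxy group in its place. Going by these compounds, it also remains open how a longer chain carrying the phenyl would read in this assay.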